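Series notes: replacing the aminopyrimidine substituent on the shared core

This account rests on a few compounds, and the source may have more. Where it says the series, first, only, none or still open, it means among the compounds named here.

Measured so far in a functional assay on NCI-H460 cells (Homo sapiens) for cytotoxicity, read by MTT assay, with a stated time of 3 days; on this read-out higher numbers stand for weaker inhibition and lower numbers for stronger inhibition:
- compound 1, `N#Cc1c(NN)nc(SCc2nc3ccccc3[nH]2)nc1-c1ccccc1`: 2.6 nM
- compound 2, `N#Cc1c(Nc2ccccc2)nc(SCc2nc3ccccc3[nH]2)nc1-c1ccccc1`: 4.54 nM
- compound 3, `N#Cc1c(Nc2ccccn2)nc(SCc2nc3ccccc3[nH]2)nc1-c1ccccc1`: 2.8 nM

All three share one core and differ only in the group carried on the nitrogen attached to it. Within this assay compound 3 stands second highest of the three numbers; its nearest neighbour is compound 1 and its furthest is compound 2, and every gap between the three lies within the scatter: a 1.7-fold higher number from compound 1 to compound 2 (0.24 log units; within the scatter), a 1.1-fold higher number from compound 1 to compound 3 (0.03 log units; within the scatter) and a 1.6-fold lower number from compound 2 to compound 3 (0.21 log units; within the scatter). Nothing here separates the three groups tried on that nitrogen.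

Compound 4, `N#Cc1c(-c2ccccc2)nc(SCc2nc3ccccc3[nH]2)nc1N1CCNCC1`, is not yet measured. It changes this position once more: piperazin-1-yl in place of (pyridin-2-yl)amino on an aromatic carbon. The three measured steps all concern the same site and none of them moved the number beyond the scatter, so they point to a small step at most. Within the data shown here, they do not, however, cover a group that sits directly on the aromatic carbon with no nitrogen linking it, as piperazin-1-yl does here; that part of the change has no precedent among the measured compounds.

On balance the step is expected to be small, a 1.6-fold higher number from compound 3 to compound 4 (0.21 log units; within the scatter), and compound 4 is estimated at 4.5 nM in this assay, with a range of 1.5 nM to 15 nM to allow for the untested mode of attachment.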

Compound 4, half-maximal inhibitory concentration: 7.35 nM
Compound 4: middle estimate off by 1.6-fold (0.21 log units), on the low side, within the range that was stated.
By their numbers in this assay, from the lowest: compounds 1, 3, 2 and 4 (each within the scatter of the next, the first and the last beyond it).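

In this assay, among these compounds, piperazin-1-yl gives the first steps beyond the scatter at this position, both modest: (a 2.6-fold higher number from compound 3 to compound 4 (0.42 log units; beyond the scatter)) against (pyridin-2-yl)amino and (a 2.8-fold higher number from compound 1 to compound 4 (0.45 log units; beyond the scatter)) against aminoamino. The anilino group does not separate in the same way (a 1.6-fold higher number from compound 2 to compound 4 (0.21 log units; within the scatter)), so compound 2 goes against any clean split between piperazin-1-yl and the three earlier groups. Among the compounds shown here, this position therefore accepts a non-aromatic ring in place of the earlier groups with only a modest shift at most, and the earlier compounds, whose steps all lay within the scatter, could not show even that much movement. Nothing shown explains the shift.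

Still open, from the compounds shown here alone, is whether the shift goes with the non-aromatic ring itself or with the attached nitrogen carrying no hydrogen, which morpholin-4-yl, 4-methylpiperazin-1-yl or an open-chain group such as dimethylamino would help to separate. Also open is whether the modest gap between piperazin-1-yl and the other groups holds in cell lines other than the one shown here.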